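A few compounds are considered here, and "the series" means these few. Any claim that something is new, unique, unknown or untested is made for them only; others in the source may bear on it.

Compound 1, `Cc1noc(C)c1NC(=O)N1CCC(c2nc(-c3ccc4ccccc4n3)no2)CC1`: 3000 nM
Compound 2, `O=C(CC1CCCCCC1)N1CCC(c2nc(-c3ccc4ccccc4n3)no2)CC1`: 840 nM
Compound 3, `CC(C)c1ccccc1NC(=O)N1CCC(c2nc(-c3ccc4ccccc4n3)no2)CC1`: 480 nM

These values come from a functional assay on Shh Light II cells (Mus musculus) for inhibition, read by a luciferase reporter; a higher number here means a weaker inhibitor, a lower number a stronger inhibitor. Compound 1 stands highest of the three; compound 2 is nearest, a 3.6-fold lower number from compound 1 to compound 2 (0.55 log units; beyond the scatter), and compound 3 furthest, a 6.3-fold lower number from compound 1 to compound 3 (0.80 log units; beyond the scatter). Compound 4, `O=C(NC1CCC(O)CC1)N1CCC(c2nc(-c3ccc4ccccc4n3)no2)CC1`, has not yet been measured and differs from compound 1 in one place: 4-hydroxycyclohexyl in place of 3,5-dimethyl-1,2-oxazol-4-yl on an amide-type nitrogen. Both measured steps bear on it. Each removes the 3,5-dimethyl-1,2-oxazol-4-yl group, and both lowered the number beyond the scatter. Going by the values given here, compound 4 keeps the amide-type nitrogen like compound 3, but enters a non-aromatic ring carrying a hydrogen-bond donor, which no measured compound shows. A modest drop is therefore expected, a 2.5-fold lower number from compound 1 to compound 4 (0.40 log units; beyond the scatter), and compound 4 is estimated at 1200 nM, within 400 nM to 3600 nM.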

Compound 4, half-maximal inhibitory concentration: 2700 nM
Compound 4: the middle estimate sits 2.3-fold (0.35 log units) below what was measured; the measured number falls inside the stated range.
By their numbers in this assay, from the lowest: compounds 3 and 2 (each within the scatter of the next); then compounds 4 and 1 (each within the scatter of the next).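

Replacing 3,5-dimethyl-1,2-oxazol-4-yl with 4-hydroxycyclohexyl on the amide-type nitrogen gives a 1.1-fold lower number from compound 1 to compound 4 (0.05 log units; within the scatter) and so shows that losing the first group is not enough for a lower number. The entering group matters: there is a 5.6-fold higher number from compound 3 to compound 4 (0.75 log units; beyond the scatter) when 4-hydroxycyclohexyl replaces 2-isopropylphenyl, and a 3.2-fold higher number from compound 2 to compound 4 (0.51 log units; beyond the scatter) in the comparison with cycloheptylmethyl on the carbonyl carbon. No supporting data explain these differences.

On these data alone, it remains open whether the hydroxyl or the non-aromatic ring accounts for the higher number. Plain cyclohexyl on the same nitrogen would separate the two.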